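A few compounds are considered here, and "the series" means these few. Any claim that something is new, unique, unknown or untested is made for them only; others in the source may bear on it.

Compound 1 `COc1nccnc1C1CN2CCC1CC2` carries a methoxy group on the core and, in a functional assay on A9L-m1 cells with A9 (Mus musculus) as the target (on this read-out lower numbers stand for smaller maximal responses and higher numbers for larger maximal responses), compound 1 gives 1%. Compound 2 `CCCCCCOc1nccnc1[C@H]1CN2CCC1CC2` carries a hexyloxy group in the same position, and in this assay compound 2 gives 46%. Within the data shown here, compound 1 thus holds the lowest of the two numbers; the gap to compound 2 lies beyond the scatter, and no step has been computed for that pair, so only the two values themselves can be compared.

Compound 3 `CCCCSc1nccnc1C1CN2CCC1CC2` is the next compound to be measured. The change from compound 1 to compound 3 is butylsulfanyl in place of methoxy on an aromatic carbon.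

Because compound 2 with its six-carbon chain reaches 46% while compound 1 stays at 1%, a four-carbon chain on sulfur is expected to lift the maximum. The step from compound 1 to compound 3 is expected to be a number 29 percentage points higher from compound 1 to compound 3 (beyond the scatter), clearly beyond the scatter. In this assay compound 3 is expected to give about 30%, within a range of 8% to 55%.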

Compound 3, largest response reached (reported as maximum), in percent of the reference or control that the assay uses: 5%
Estimate against measurement, compound 3: 25 percentage points above; measured number outside the range, below it.
By their numbers in this assay, from the lowest: compounds 1 and 3 (each within the scatter of the next); then compound 2.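

In this assay, butylsulfanyl in place of methoxy on an aromatic carbon next to the ring nitrogen gives a number 4 percentage points higher from compound 1 to compound 3 (within the scatter) and so does not separate from methoxy at this position, even with 5 heavy atoms in place of 2. A longer group at this position is therefore not enough on its own for a large maximal response: of the three compounds, only compound 2, with hexyloxy, gives a value beyond the scatter of the others, at 46% in this assay as measured. No measurement at hand gives a reason for this result.

Still open, on these data alone, is whether chain length or the sulfur in place of oxygen matters more at this position. A butoxy group and a hexylsulfanyl group on the shared core would separate these two changes, and an amine at the same carbon would test a different kind of attached atom.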